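This account rests on a few compounds, and the source may have more. Where it says the series, first, only, none or still open, it means among the compounds named here.

The series is followed in a functional assay on HT-29 cells (Homo sapiens) for antiproliferative activity, with a stated time of 48 h; on this read-out higher numbers stand for weaker inhibition and lower numbers for stronger inhibition. Compound 1, with the structure `CCCCC(OC)c1cccc(NC(=O)CCl)c1`, gives 13000 nM in this assay. Compound 2, with the structure `CCCCC(O)c1cccc(NC(=O)CCCCl)c1`, gives only a limit in this assay, > 100000 nM, so its true value is not known as a number. Compound 2 thus sits at the limit of > 100000 nM in this assay, at which 1 of the 2 values shown sits, and its standing against compound 1 cannot be put into a numbered step. Compound 3, with the structure `CCCCC(OC)c1cccc(NC(=O)CCCCl)c1`, has not yet been measured in this assay. Compound 3 differs from compound 2 by a single change: methyl in place of hydrogen on an oxygen on a saturated carbon. No measured pair shows this change on its own, so its size cannot be read from the numbers shown. What the two values show is that compound 1, which carries the methoxy group, has a value as a number, while compound 2, which carries the hydroxy group, reaches only a limit. Compound 3 is therefore expected to land around 60000 nM, with a likely range from 15000 nM to 200000 nM. The step of an at least 1.6-fold lower number from compound 2 to compound 3 (0.22 log units; that floor lies within the scatter) is estimated to be modest, toward stronger inhibition at best, with a fair chance that the assay again reports only a limit.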

Compound 3, half-maximal inhibitory concentration: > 100000 nM
Compound 3 ended at the assay's limit; the forecaster's own chance of this, stated with the estimate: 45%; at least 1.6-fold (0.22 log units) between middle value and limit.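

Compound 3 is again only a limit of the assay in this assay, at > 100000 nM. Compound 2 is also a limit, so the step from hydroxy to methoxy on this oxygen on a saturated carbon cannot be read, and the result gives no size for that change with the 2-chloroethyl group in place. What the result adds is the first readable step in the series, which comes from the other part of the molecule: with the methoxy group held constant, 2-chloroethyl in place of chloro on a saturated chain carbon bound to a carbonyl carbon gives an at least 7.6-fold higher number from compound 1 to compound 3 (0.88 log units; beyond the scatter), a change toward weaker inhibition, and the series now gathers at the end of the measurable range: the limit of > 100000 nM in this assay, at which 2 of the 3 values shown sit.

On these data alone, it remains open whether the same swap of hydrogen for methyl on this oxygen has any measurable size when the chloro group of compound 1 is present. Also open, as far as these compounds go, is whether an ethoxy group on the same saturated carbon, or an amine in place of the chloro on the chain, would bring the values back into the numbered range.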